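Shortening the amine chain of a weak binder

The compounds below may be only part of what the source reports. "The series", "measured", "known", "first", "only" and "open" are said of these compounds alone.

Compound 1, `c1ccc2cc(N3CCNCC3)ccc2c1`, gives 32 nM in an in vitro assay on NG 108-15 cells for binding affinity to Serotonin 3 (5-HT3) receptor (Homo sapiens); a lower number here means a stronger inhibitor, a higher number a weaker inhibitor.
Compound 2, `N=C(N)NC(=O)Nc1cccc(Cl)c1`, gives 1250 nM in this assay.
Compound 3, `NCCCCc1cccc(Cl)c1`, gives > 10000 nM in this assay.

Compound 3 stands apart from the other two: its value in this assay is a limit of the assay and not a number, so only its weakness is known. This is the limit of > 10000 nM in this assay, at which 1 of the 3 values shown sits, the weakest position among the three measured entries, while compound 1 and compound 2 each carry a measured value.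

Compound 4, `NCCCc1cccc(Cl)c1`, differs from compound 3 by amino in place of aminomethyl on a saturated chain carbon, three bonds along the chain from an aromatic carbon. For the measured compounds named here, no measured pair in this assay shows a change of this kind, so the size of the step cannot be read from the data. Starting from a limit, the step from compound 3 to compound 4 is expected to be small or none beyond the scatter, the estimate being a step that the limit leaves unreadable from compound 3 to compound 4. Compound 4 is therefore estimated at 15000 nM in this assay, within a range from 3000 nM to 60000 nM, with a good chance that only a limit is reported again.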

Compound 4, inhibition constant: > 10000 nM
Compound 4: a limit, no number; the forecaster's own chance of this, stated with the estimate: 70%; the middle value lies beyond the limit too.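

Compound 3 and compound 4 both stand at a limit of this assay and not at a number, so no step can be read between them: the limit of > 10000 nM in this assay, at which 2 of the 4 values shown sit.

The compounds shown leave open whether changing the length of this amine chain alters binding at all.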